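Cytotoxicity notes on a shared-core series

The source may hold more compounds than are shown below. What is called first, only, known or untested is meant among the compounds shown, and "the series" means these compounds.

Measured compounds:
Compound 1, `Cn1cc(SCc2nnc(SCc3ccccc3Cl)n2-c2c(Cl)cccc2Cl)c2ccccc21`: 49600 nM
Compound 2, `Cn1cc(SCc2nnc(SCc3cc(C(F)(F)F)ccc3Cl)n2-c2c(Cl)cccc2Cl)c2ccccc21`: 53800 nM
Compound 3, `Cn1cc(SCc2nnc(SCc3cc(Cl)ccc3Cl)n2-c2c(Cl)cccc2Cl)c2ccccc21`: > 100000 nM (a limit)

In a toxicity assay on HEK-293T cells (Homo sapiens) for cytotoxicity, read by CCK-8 assay, with a stated time of 48 h (on this read-out lower numbers stand for higher toxicity in this test and higher numbers for lower toxicity in this test), compound 1 gives 49600 nM and compound 2 gives 53800 nM; the step of a 1.1-fold higher number from compound 1 to compound 2 (0.04 log units; within the scatter). For compound 3 this assay reports only a limit, > 100000 nM, and not a number. Compound 3 therefore stands at the top of the numbers shown, described by an at least 2.0-fold higher number from compound 1 to compound 3 (0.30 log units; that floor lies within the scatter) and an at least 1.8-fold higher number from compound 2 to compound 3 (0.26 log units; that floor lies within the scatter), and by the limit of > 100000 nM in this assay, at which 1 of the 3 values shown sits.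

Compound 4, `Cn1cc(SCc2nnc(SCc3ccc(OC(F)(F)F)c(Cl)c3)n2-c2c(Cl)cccc2Cl)c2ccccc21`, differs from compound 3 by 3-chloro-4-(trifluoromethoxy)phenyl in place of 2,5-dichlorophenyl on a saturated chain carbon bound to a sulfur. Among the measured compounds shown here, no measured pair changes the whole substituted phenyl; the measured steps change single groups on that ring, and each of them, a 1.1-fold higher number from compound 1 to compound 2 (0.04 log units; within the scatter), an at least 2.0-fold higher number from compound 1 to compound 3 (0.30 log units; that floor lies within the scatter) and an at least 1.8-fold higher number from compound 2 to compound 3 (0.26 log units; that floor lies within the scatter), lies within the scatter or has a floor within it. On that basis no step beyond the scatter is expected in this assay from compound 3 to compound 4, which the estimate a number no higher from compound 3 to compound 4 (the limit leaves the size open) expresses. Compound 4 is estimated at 100000 nM, with a range from 45000 nM to 220000 nM, and a fair chance that this assay again returns only a limit.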

Compound 4, half-maximal cytotoxic concentration: 77700 nM
Beside the measured number, compound 4's estimate is 1.3-fold (0.11 log units) above it; the measured number falls inside the stated range.
By their numbers in this assay, from the lowest: compounds 1, 2 and 4 (each within the scatter of the next). At a limit, above all of these: compound 3.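

In this assay, among the compounds shown here, the whole substituted phenyl on the saturated chain carbon bound to a sulfur is exchanged for the first time, and the entering 3-chloro-4-(trifluoromethoxy)phenyl brings an oxygen into a group that so far held only carbon and halogens; both steps that can be sized lie within the scatter: a 1.4-fold higher number from compound 2 to compound 4 (0.16 log units; within the scatter) and a 1.6-fold higher number from compound 1 to compound 4 (0.19 log units; within the scatter). Compound 4 thus extends the tolerated range of this position from single-group exchanges on the ring to a different substitution pattern with a larger group, with no step beyond the scatter among the three compounds that carry numbers. The comparison with the remaining compound gives only a floor, an at least 1.2-fold lower number from compound 3 to compound 4 (0.10 log units; that floor lies within the scatter), and compound 3 stays a limit and not a number: the limit of > 100000 nM in this assay, at which 1 of the 4 values shown sits.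

Every group shown at this position is a chlorinated phenyl, so the outcome with an amine, a carboxylic acid or a longer chain in its place stays open. Whether any exchange here can move the number beyond the scatter also stays open, as does the effect of changes elsewhere on the shared core, which is the same in all the compounds shown.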